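The source may hold more compounds than are shown below. What is called first, only, known or untested is meant among the compounds shown, and "the series" means these compounds.

Within the data shown here, compound 1, `COc1ccc(-c2cncnc2-c2cc(OC)c(OC)c(OC)c2)cc1F`, is one of two compounds measured so far in a functional assay on HeLa cells (Homo sapiens) for antiproliferative activity, read by CCK-8 assay, with a stated time of 72 h; a lower number here means a stronger inhibitor, a higher number a weaker inhibitor. Compound 1 gives 500 nM, the highest of the two numbers shown. Its nearest neighbour is compound 2, `CCOc1ccc(-c2cncnc2-c2cc(OC)c(OC)c(OC)c2)cc1F`, which in this assay gives 470 nM. Among the measured compounds shown here, the only step available, a 1.1-fold lower number from compound 1 to compound 2 (0.03 log units; within the scatter), is a methyl in place of hydrogen on a saturated chain carbon bound to an oxygen on an aromatic ring.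

Compound 3, `COc1cc(-c2ncncc2-c2ccc3cc[nH]c3c2)cc(OC)c1OC`, has not yet been measured in this assay. It differs from compound 1 in one place: 1H-indol-6-yl in place of 3-fluoro-4-methoxyphenyl on an aromatic carbon. The change sits on an aromatic carbon of a six-membered aromatic ring with two nitrogens, ortho to a large group.

For the measured compounds named here, none of the measured steps touches this part of the shared core; the one step that exists concerns the other ring and was within the scatter. The data therefore give no direct guide to the size or direction of the step, so the expectation rests on the value of compound 1 alone. Compound 3 is estimated at 350 nM, with a wide range from 60 nM to 2000 nM, an expected step of a 1.4-fold lower number from compound 1 to compound 3 (0.15 log units; within the scatter).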

Compound 3, half-maximal inhibitory concentration: 770 nM
The estimate for compound 3 lay 2.2-fold (0.34 log units) below the measured number; the measured number falls inside the stated range.
By their numbers in this assay, from the lowest: compounds 2, 1 and 3 (each within the scatter of the next).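

Among these compounds, the one earlier step changed only the chain on an oxygen, whereas this step replaces the whole 3-fluoro-4-methoxyphenyl group, and in this assay it comes out as a 1.5-fold higher number from compound 1 to compound 3 (0.19 log units; within the scatter). At this aromatic carbon, then, 1H-indol-6-yl, which brings a five-membered aromatic ring and a hydrogen-bond donor and leaves out the fluorine and the oxygen of the old group, gives a number that cannot be told apart from that of compound 1. Nothing available here explains why two such different groups read alike in this test.

The compounds shown still leave open whether the hydrogen on the indole nitrogen matters, since no compound here has a methyl group in its place. As far as these compounds go, they also give no reading for a simple phenyl group at this position, or for a phenyl group carrying an amine or a carboxylic acid, so it remains unknown whether any change at this carbon can move the number beyond the scatter.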